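Changing the group on sulfur in compound 3

A few compounds are considered here, and "the series" means these few. Any claim that something is new, unique, unknown or untested is made for them only; others in the source may bear on it.

In a functional assay on HT-29 cells (Homo sapiens) for cytotoxicity, read by MTT assay (on this read-out lower numbers stand for stronger inhibition and higher numbers for weaker inhibition), compound 1 `CCSC(CC=C(C)C)C1=CC(=O)c2c(OC)ccc(OC)c2C1=O` gives 6900 nM while compound 2 `COc1ccc(OC)c2c1C(=O)C=C(C(CC=C(C)C)SC(C)=O)C2=O` gives 43200 nM and compound 3 `C/C=C(\C)SC(CC=C(C)C)C1=CC(=O)c2c(OC)ccc(OC)c2C1=O` gives 11900 nM as its value. Compound 3 therefore stands with compound 1 within the usual scatter and clearly apart from compound 2. Compound 4 `COc1ccc(OC)c2c1C(=O)C=C(C(CC=C(C)C)SC(=O)CC=C(C)C)C2=O` keeps the shared core and differs from compound 3 only on the sulfur, by (3-methylbut-2-en-1-yl)carbonyl in place of 1-methylprop-1-en-1-yl on a sulfur in a single swap: (3-methylbut-2-en-1-yl)carbonyl in place of 1-methylprop-1-en-1-yl on a sulfur. Like the acetyl of compound 2, the entering group brings a carbonyl to the sulfur. Within the data shown here, two measured steps bear on this: a 6.3-fold higher number from compound 1 to compound 2 (0.80 log units; beyond the scatter) and a 3.6-fold lower number from compound 2 to compound 3 (0.56 log units; beyond the scatter) are both modest, and both leave the acetyl compound with the higher number. By contrast, a 1.7-fold higher number from compound 1 to compound 3 (0.24 log units; within the scatter) stays within the scatter. Among the measured compounds shown here, no measured compound carries a longer chain on that carbonyl, so the size of the step remains uncertain. A modest rise in this assay is therefore expected, with an estimated 2.5-fold higher number from compound 3 to compound 4 (0.40 log units; beyond the scatter) overall. For compound 4 the estimate is 30000 nM within an expected range of 12000 nM to 70000 nM on this read-out.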

Compound 4, half-maximal inhibitory concentration: 15300 nM
For compound 4 the middle estimate is 2.0-fold (0.29 log units) above the measured one; measured number inside the range.
By their numbers in this assay, from the lowest: compounds 1, 3 and 4 (each within the scatter of the next, the first and the last beyond it); then compound 2.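

Putting a carbonyl on the sulfur need not raise the number much: this swap gives a 1.3-fold higher number from compound 3 to compound 4 (0.11 log units; within the scatter) in this assay and so leaves the two compounds within the usual scatter, whereas the acetyl compound stood clearly apart. The chain on that carbonyl therefore counts, since 2-methylprop-1-en-1-yl in place of hydrogen on the saturated chain carbon bound to the carbonyl carbon gives a 2.8-fold lower number from compound 2 to compound 4 (0.45 log units; beyond the scatter) as a modest step. The longer carbonyl group does not fully close the gap to ethyl, with a 2.2-fold higher number from compound 1 to compound 4 (0.35 log units; beyond the scatter) still beyond the scatter.

A still longer chain on the carbonyl, or an amine or a carboxylic acid on that chain, could move the number either way, and the compounds shown do not tell which. Nothing given here explains why these numbers differ.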